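The compounds below may be only part of what the source reports. "The series", "measured", "known", "first", "only" and "open" are said of these compounds alone.

Compound 3 `C=CC(=O)Nc1cc(Nc2ncc(Cl)c(Nc3ccc(F)c(Cl)c3)n2)c(OC)cc1N1CCN(C)CC1` sits second highest of the three numbers in a functional assay on NCI-H1975 cells (Homo sapiens) for inhibition, read by CellTiter-Glo, with a stated time of 72 h; a lower number here means a stronger inhibitor of growth, a higher number a weaker inhibitor of growth. Compound 1 `C=CC(=O)Nc1cc(Nc2ncc(C)c(Nc3ccccc3S(=O)(=O)C(C)C)n2)c(OC)cc1N1CCN(CC)CC1` gives 43 nM and compound 2 `C=CC(=O)Nc1cc(Nc2nccc(Nc3ccccc3S(=O)(=O)C(C)C)n2)c(OC)cc1N1CCN(CC)CC1` gives 190 nM; compound 3 gives 100 nM, within the scatter of compound 2 and beyond it from compound 1. Going by the values given here, the one measured step, a 4.4-fold higher number from compound 1 to compound 2 (0.65 log units; beyond the scatter), concerns the shared core and does not touch the change at hand.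

Compound 4 `C=CC(=O)Nc1cc(Nc2ncc(Cl)c(Nc3ccccc3S(=O)(=O)N(C)C)n2)c(OC)cc1N1CCN(C)CC1` differs from compound 3 by 2-(dimethylsulfamoyl)phenyl in place of 3-chloro-4-fluorophenyl on a nitrogen on an aromatic ring. Among the compounds with values here, no measured pair bears on this swap directly. Compounds 1 and 2, which carry a sulfonyl-bearing phenyl on a nitrogen on an aromatic ring whose other neighbours are aromatic carbon, bracket compound 3 on either side, so a sulfur-bearing substituent in this position is compatible with numbers near those of compound 3. The step from compound 3 to compound 4 is therefore expected to be small, a 1.4-fold lower number from compound 3 to compound 4 (0.15 log units; within the scatter), with no clear direction beyond the scatter. Compound 4 is estimated at 70 nM in this assay, between 25 nM and 200 nM.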

Compound 4, concentration for 50% growth inhibition: 31 nM
Estimate against measurement, compound 4: 2.3-fold (0.35 log units) above; the range from low to high includes it.
By their numbers in this assay, from the lowest: compounds 4 and 1 (each within the scatter of the next); then compounds 3 and 2 (each within the scatter of the next).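

Going by these compounds alone, the step at this position is the first direct one: 2-(dimethylsulfamoyl)phenyl in place of 3-chloro-4-fluorophenyl on a nitrogen on an aromatic ring gives a 3.2-fold lower number from compound 3 to compound 4 (0.51 log units; beyond the scatter) in this assay. The earlier step changed only an aromatic carbon of the shared core, so this result adds that the group on this nitrogen also moves the growth-inhibition number, and that a halogen-free group carrying a sulfonyl can replace the chlorinated, fluorinated ring without loss. No measurement shown accounts for the step.

The swap changes the whole group at once, so the share of the sulfonyl, the two methyl groups on its nitrogen and the loss of both halogens stays unresolved. Also open, from the compounds shown here alone, is how an unsubstituted sulfamoyl group or a carboxylic acid would behave on the same phenyl ring.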